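This account rests on a few compounds, and the source may have more. Where it says the series, first, only, none or still open, it means among the compounds named here.

Series notes. The shared core of compound 1 `CC1(C)OC(C)(C)c2c1nnc(-c1ccccc1)[n+]2[O-]` carries a plain phenyl; in a functional assay on the whole organism with Mus musculus as the target (on this read-out lower numbers stand for an effect already at smaller amounts and higher numbers for an effect only at larger amounts of compound), compound 1 gives 163 mg/kg. Compound 2 `CC1(C)OC(C)(C)c2c1nnc(-c1cccc([N+](=O)[O-])c1)[n+]2[O-]` gives 72 mg/kg in this assay, and compound 3 `CC1(C)OC(C)(C)c2c1nnc(-c1cccc(F)c1)[n+]2[O-]` gives 74.9 mg/kg. Compound 2 has the lowest number of the three measured, but compound 3 sits within the scatter of it, a 1.0-fold higher number from compound 2 to compound 3 (0.02 log units; within the scatter), so the two cannot be ranked against each other; only compound 1 stands clearly apart, with a 2.3-fold lower number from compound 1 to compound 2 (0.35 log units; beyond the scatter) and a 2.2-fold lower number from compound 1 to compound 3 (0.34 log units; beyond the scatter).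

Compound 4 `Cc1cccc(-c2nnc3c([n+]2[O-])C(C)(C)OC3(C)C)c1` is not yet measured. It differs from compound 2 by methyl in place of nitro on an aromatic carbon. Going by the values given here, no measured step covers a methyl on this ring. Among the compounds with values here, the steps that bear on it are the two from compound 1, where two quite different groups entering each gave a modest drop in the number, and the flat step between compound 2 and compound 3. Whether a methyl behaves like those two groups or like hydrogen is open, so the expected number for compound 4 in this assay is placed between them, leaning toward compound 2 since both measured substituents moved the same way. Compound 4 is expected to give 95 mg/kg, with a range from 50 mg/kg to 190 mg/kg. That estimate implies a step of a 1.3-fold higher number from compound 2 to compound 4 (0.12 log units; within the scatter), which may well stay within the scatter.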

Compound 4, dose for half-maximal effect: 150 mg/kg
Compound 4: the middle estimate sits 1.6-fold (0.20 log units) below what was measured, and the stated range covers the measured number.
By their numbers in this assay, from the lowest: compounds 2, 3, 4 and 1 (each within the scatter of the next, the first and the last beyond it).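

Notes on the methyl step. In this assay, methyl on this aromatic carbon, meta to a large group, cannot be told apart from hydrogen (a 1.1-fold lower number from compound 1 to compound 4 (0.04 log units; within the scatter)), so carrying a group here is not enough in itself to give the lower numbers seen with nitro and fluoro. Nitro and methyl are separated at this same place (a 2.1-fold higher number from compound 2 to compound 4 (0.32 log units; beyond the scatter)), which makes this the first measured step beyond the scatter between two substituted compounds and shows that the identity of the group matters here. Methyl in place of fluoro stays within the scatter (a 2.0-fold higher number from compound 3 to compound 4 (0.30 log units; within the scatter)), so compound 3 cannot be separated from either compound 2 or compound 4, even though those two are separated from each other, and its place relative to the methyl compound remains unresolved.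

Going by these compounds, whether an amine, a carboxylic acid or a longer chain at this place would fall with nitro and fluoro or with methyl and hydrogen remains open. On these data alone, what sets nitro and fluoro apart from methyl also remains open, as no measurement at hand bears on it.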